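Semicarbazone aryl exchange and expected cytotoxicity on WI-38 cells

The source may hold more compounds than are shown below. What is called first, only, known or untested is meant among the compounds shown, and "the series" means these compounds.

Compounds with numbers so far:
- compound 1 `COc1ccc(OC)c(/C=N/NC(=O)Nc2ccc(Oc3ccnc(-c4nncn4CCN(C)C)c3)c(F)c2)c1`: "not determined" (no result reported) in an ADME assay on WI-38 cells (Homo sapiens) for cytotoxicity, read by MTT assay, with a stated time of 72 h; a higher number here means a weaker inhibitor, a lower number a stronger inhibitor
- compound 2 `COc1ccc(/C=N/NC(=O)Nc2ccc(Oc3ccnc(-c4nncn4CCN(C)C)c3)c(F)c2)c(OC)c1OC`: "not determined" (no result reported) in this assay
- compound 3 `CN(C)CCn1cnnc1-c1cc(Oc2ccc(NC(=O)N/N=C/c3ccccc3O[N+](=O)[O-])cc2F)ccn1`: 6860 nM in this assay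

Compound 1 stands without a single number in this assay, and compound 2 is the second entry of the set that also lacks one. Going by the values given here, only compound 3 supplies a measured value, and with no pair of measured compounds differing in one place there is no step from which the size of an effect could be read.

Compound 4 `CN(C)CCn1cnnc1-c1cc(Oc2ccc(NC(=O)N/N=C/c3ccc(F)cc3F)cc2F)ccn1` arises from compound 1 by the change (2,4-difluorophenyl in place of 2,5-dimethoxyphenyl on a carbon with a double bond to nitrogen), that is, 2,4-difluorophenyl in place of 2,5-dimethoxyphenyl on a carbon with a double bond to nitrogen. Since compound 1 itself has no number, no direction can be assigned to this step from the data; what is shown is only the value of the one compound that shares the core of compound 1 with a different aryl group on the same carbon, and that compound 3 gives 6860 nM.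

On that basis compound 4 is expected to lie in the same region as compound 3, with no step beyond the scatter anticipated in either direction, and its estimated value is 7000 nM with a range from 2500 nM to 20000 nM.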

Compound 4, half-maximal inhibitory concentration: 5030 nM
The estimate for compound 4 lay 1.4-fold (0.14 log units) above the measured number; the range from low to high includes it.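

In this assay the group on a carbon with a double bond to nitrogen now gives its first readable step, since the exchange of 2-(nitrooxy)phenyl for 2,4-difluorophenyl produces a 1.4-fold lower number from compound 3 to compound 4 (0.13 log units; within the scatter) and the two groups cannot be told apart on this reading. Two quite different aryl groups on the shared core thus give values within the scatter of each other, where earlier a single value stood alone and the position could not be judged at all. Nothing independent of these numbers bears on this outcome.

Steps involving compound 1 and compound 2 cannot be read, and the 2,5-dimethoxyphenyl group and the trimethoxyphenyl group of compound 2 therefore remain unplaced against the two aryl groups that have values. Also open, as far as these compounds go, is whether a phenyl ring carrying a carboxylic acid or a primary amine on this same carbon would move the number in this assay beyond the scatter, or whether this position tolerates such exchanges as well.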